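Chloro for fluoro on the aniline of quinazoline sulfonamides

The source may report more compounds than this note shows. Statements on the series, on what has been measured and on what is new or still open speak of the compounds shown alone.

Compound 1 `COc1cc2ncnc(Nc3ccc(F)cc3)c2cc1OCCCCC(=O)Nc1ccc(S(N)(=O)=O)cc1` is tested in a functional assay on NCI-H1975 cells (Homo sapiens) for antiproliferative activity, read by MTT assay, with a stated time of 72 h; a higher number here means a weaker inhibitor, a lower number a stronger inhibitor. In that assay compound 1 reaches only the limit > 40000 nM, which is not a number but the limit itself (the limit of > 40000 nM in this assay, at which 1 of the 3 values shown sits). Compound 2 `COc1cc2ncnc(Nc3ccc(Cl)cc3)c2cc1OCCCCC(=O)Nc1ccc(S(N)(=O)=O)cc1` differs by chloro in place of fluoro on an aromatic carbon and gives 31800 nM in this assay; the step of an at least 1.2-fold lower number from compound 1 to compound 2 (0.09 log units; that floor lies within the scatter) is measured. Compound 3 `NS(=O)(=O)c1ccc(NC(=S)Nc2ccc3ncnc(Nc4cccc(F)c4)c3c2)cc1` carries a different core; how the cores of compound 1 and compound 3 differ is not broken down here. In this assay compound 3 gives 9660 nM, the lowest of the two numbers recorded.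

Compound 4 `NS(=O)(=O)c1ccc(NC(=S)Nc2ccc3ncnc(Nc4cccc(Cl)c4)c3c2)cc1` is not yet measured and differs from compound 3 by chloro in place of fluoro on an aromatic carbon. This is the same kind of change as from compound 1 to compound 2, not the same: there the place is para to a large group, here it is meta to a large group. The step from compound 3 to compound 4 is expected to be about a 1.5-fold lower number from compound 3 to compound 4 (0.17 log units; within the scatter) in this assay, resting on the measured step of an at least 1.2-fold lower number from compound 1 to compound 2 (0.09 log units; that floor lies within the scatter), which was small and from a limit. Compound 4 is therefore estimated at 6500 nM, between 2500 nM and 16000 nM.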

Compound 4, half-maximal inhibitory concentration: 39800 nM
Estimate against measurement, compound 4: 6.1-fold (0.79 log units) below, outside the stated range (above it).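

In this assay, chloro in place of fluoro gives a 4.1-fold higher number from compound 3 to compound 4 (0.61 log units; beyond the scatter), so on these two cores the change does not carry over as a step of one size: the same change on two cores in this assay, an at least 1.2-fold lower number (0.09 log units; that floor lies within the scatter) from compound 1 to compound 2 and a 4.1-fold higher number (0.61 log units; beyond the scatter) from compound 3 to compound 4, at least 5.1-fold (0.71 log units) apart, beyond the scatter of two such steps. Going by these compounds, the earlier step starts from a limit of the assay, not a number, so its full size stays unknown: the limit of > 40000 nM in this assay, at which 1 of the 4 values shown sits. Among the compounds shown here, the result rests on only two pairs, which differ in the place of the halogen as well as in the core, so it does not show whether the core or the place separates the two steps, and it gives no general rule for the series.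

Still open, on these data alone, is whether bromo or methoxy at the same place on the core of compound 3 would follow the step from fluoro to chloro. Also open, as far as these compounds go, is how the 3-fluorophenyl and 3-chlorophenyl pair would behave on the core of compound 1, and whether a carboxylic acid in place of the sulfonamide would alter the step.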